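This account rests on a few compounds, and the source may have more. Where it says the series, first, only, none or still open, it means among the compounds named here.

Measured compounds:
- compound 1 `COC(=O)c1ccc(NC(=O)[C@H]2CC=C(CCC=C(C)C)C[C@@H]2c2ccccc2)cc1` — an assay on isolated protein for inhibition of Apoptosis regulator Bcl-2 (Homo sapiens), read by fluorescence polarization, with stated times of 5 min and 10 min; a lower number here means a stronger inhibitor, a higher number a weaker inhibitor: > 23000 nM
- compound 2 `CON(C)C(=O)[C@@H]1CC2=C(CCCC2(C)C)C[C@H]1c1ccccc1` — this assay: > 23000 nM
- compound 3 `CC(C)=CCCC1=CC[C@@H](C(=O)NCCC(=O)O)[C@H](c2ccccc2)C1` — this assay: > 23000 nM

Compound 1 stands at a limit of the assay, not at a number; its value is > 23000 nM and says only that no inhibition constant could be read out. The same holds for compound 2, whose result is > 23000 nM. Compound 3 likewise sits at > 23000 nM, a limit. All three values therefore rest on (the limit of > 23000 nM in this assay, at which 3 of the 3 values shown sit), and no ordering among compounds 1, 2 and 3 can be drawn from them.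

Compound 4 `CC(C)=CCCC1=CC[C@H](C(=O)Nc2ccc(C(=O)O)cc2)[C@@H](c2ccccc2)C1` is to be measured in this assay. It differs from compound 1 by hydrogen in place of methyl on an oxygen next to a carbonyl group. Compound 3, which also carries a carboxy group on a different chain, gave only the limit, so nothing measured here points towards a gain for compound 4.

The expectation is that the step that the limit leaves unreadable from compound 1 to compound 4 will be nil beyond the scatter, with compound 4 most likely again reported as a limit. Compound 4 is estimated at 35000 nM, between 8000 nM and 150000 nM.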

Compound 4, inhibition constant: > 23000 nM
Compound 4: only a limit was reported; the forecaster's own chance of this, stated with the estimate: 80%; the middle value lies beyond the limit too.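

No step can be read between compound 1 and compound 4, since both results in this assay are limits and not numbers: the limit of > 23000 nM in this assay, at which 4 of the 4 values shown sit.

The compounds shown leave open whether hydrogen in place of methyl on that oxygen changes binding at all, and which structural change, if any, would give a readable inhibition constant in this assay.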